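Benzyl substitution change at the ring-bound amine nitrogen

The compounds below may be only part of what the source reports. "The series", "measured", "known", "first", "only" and "open" are said of these compounds alone.

The series shares one core and varies the substituent on the amine attached to an aromatic carbon. Compound 1 `CCC(CC)Nc1cc(C)nc2c(-c3cnc(N(C)C)cc3C)c(C)nn12` in an assay on CHO cells for binding affinity to corticotropin-releasing factor receptor 1 (Homo sapiens) (on this read-out lower numbers stand for stronger inhibition and higher numbers for weaker inhibition), gives 9.4 nM. Within the data shown here, compound 2 `CCCCN(CCCC)c1cc(C)nc2c(-c3cnc(N(C)C)cc3C)c(C)nn12` gives 4.2 nM; the step of a 2.2-fold lower number from compound 1 to compound 2 (0.35 log units; beyond the scatter) is the only measured step in the set. Compound 3 `CCN(Cc1ccccc1C)c1cc(C)nc2c(-c3cnc(N(C)C)cc3C)c(C)nn12` gives 2.4 nM, the lowest of the three numbers; against compound 2 the two values lie within the scatter, while against compound 1 the gap is beyond it.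

Compound 4 `CCN(Cc1ccc(Cl)c(Cl)c1)c1cc(C)nc2c(-c3cnc(N(C)C)cc3C)c(C)nn12` differs from compound 3 by 3,4-dichlorophenyl in place of 2-methylphenyl on a saturated chain carbon bound to a nitrogen on an aromatic ring. Among the measured compounds shown here, no measured step touches the substituent on the benzyl group; the single measured step concerns a different change at the amine, and it was modest. With nothing that bears directly on this change, the expectation for compound 4 in this assay is a step of a 1.3-fold higher number from compound 3 to compound 4 (0.10 log units; within the scatter), no direction beyond the scatter. The estimate for compound 4 is 3 nM, within 1 nM to 9 nM.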

Compound 4, inhibition constant: 2.5 nM
Compound 4: the middle estimate sits 1.2-fold (0.08 log units) above what was measured; the range from low to high includes it.
By their numbers in this assay, from the lowest: compounds 3, 4 and 2 (each within the scatter of the next); then compound 1.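

In this assay, 3,4-dichlorophenyl in place of 2-methylphenyl on a saturated chain carbon bound to a nitrogen on an aromatic ring gives a 1.0-fold higher number from compound 3 to compound 4 (0.02 log units; within the scatter) and so leaves the read-out unmoved within the scatter. Among these compounds, the earlier compounds carried only one benzyl group and gave no view of the phenyl substitution; this pair shows that the two patterns, 2-methylbenzyl and 3,4-dichlorobenzyl, cannot be told apart on this read-out. Nothing available explains why the two patterns read alike.

On these data alone, whether an amine or a carboxylic acid on the phenyl ring would keep the number this flat remains open. Also open, as far as these compounds go, is what a longer chain in place of the ethyl group on the same nitrogen would do with either benzyl group in place.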